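The source may hold more compounds than are shown below. What is called first, only, known or untested is meant among the compounds shown, and "the series" means these compounds.

In a physicochemical assay for solubility, read by nephelometry, measured as kinetic solubility, at pH 2, tested at 10 mg/mL (on this read-out higher numbers stand for higher solubility and lower numbers for lower solubility), compound 1 (`Cc1c(F)cccc1C(=O)Nc1cc(Cl)ccn1`) gives 12.5 ug/mL and compound 2 (`Cc1c(C(=O)Nc2ccccn2)ccc(F)c1F`) gives 50 ug/mL as the higher of the two numbers, a gap beyond the usual scatter. Compound 3 (`Cc1c(F)cccc1C(=O)Nc1ccccn1`) has not yet been measured. Set against compound 2, it carries hydrogen in place of fluoro on an aromatic carbon. Going by the values given here, no measured pair of compounds shows this swap on its own, so in this assay the expected step (a 1.2-fold higher number from compound 2 to compound 3 (0.08 log units; within the scatter)) is none beyond the scatter. The estimated value for compound 3 is 60 ug/mL (expected range 25 ug/mL to 150 ug/mL).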

Compound 3, solubility: 50 ug/mL
Compound 3: middle estimate off by 1.2-fold (0.08 log units), on the high side; low and high end bracket the measured number.
By their numbers in this assay, from the lowest: compound 1; then compounds 2 and 3 (each within the scatter of the next).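

In this assay, hydrogen in place of fluoro on an aromatic carbon, ortho to a fluoro group, gives no change at the digits printed from compound 2 to compound 3 (within the scatter), so the read-out holds through this swap at this position. Hydrogen in place of chloro on an aromatic carbon instead gives a 4.0-fold higher number from compound 1 to compound 3 (0.60 log units; beyond the scatter), so among these three compounds the chloro swap moves the number and the fluoro swap does not. Nothing measured here explains either result.

On these data alone, whether an amine or a carboxylic acid at the fluoro position would move the number remains open. So does the effect of a methoxy group at the chloro position.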